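Indole for Benzothiophene at the Anilino Nitrogen

The source may report more compounds than this note shows. Statements on the series, on what has been measured and on what is new or still open speak of the compounds shown alone.

Compound 1 `Cn1c(=O)c(S(=O)(=O)c2ccc(F)cc2F)cc2cnc(Nc3ccc4sccc4c3)nc21`: 500 nM
Compound 2 `Cn1c(=O)c(S(=O)(=O)c2ccc(OC(=O)CCCCC3SCC4NC(=O)NC43)cc2)cc2cnc(Nc3ccc4[nH]ccc4c3)nc21`: 150 nM

In a functional assay on DU-145 cells (Homo sapiens) for inhibition, read by trypan blue exclusion, with a stated time of 72 h (on this read-out lower numbers stand for stronger inhibition and higher numbers for weaker inhibition), compound 1 gives 500 nM, the higher of the two numbers shown; compound 2 gives 150 nM, a gap beyond the scatter, though the two also differ elsewhere. Compound 3 `Cn1c(=O)c(S(=O)(=O)c2ccc(F)cc2F)cc2cnc(Nc3ccc4cc[nH]c4c3)nc21` carries 1H-indol-6-yl in place of 1-benzothiophen-5-yl on a nitrogen on an aromatic ring. Among the compounds with values here, no measured pair isolates this change, so the step of a 1.4-fold lower number from compound 1 to compound 3 (0.15 log units; within the scatter) is expected to be small, likely toward a lower number but possibly within the scatter. Compound 3 is therefore estimated at 350 nM, with a range from 120 nM to 1000 nM.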

Compound 3, half-maximal inhibitory concentration: 5000 nM
For compound 3 the middle estimate is 14-fold (1.15 log units) below the measured one; the measured number lies above the stated range.
By their numbers in this assay, from the lowest: compound 2; then compound 1; then compound 3.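

In this assay, 1H-indol-6-yl in place of 1-benzothiophen-5-yl on a nitrogen on an aromatic ring gives a 10-fold higher number from compound 1 to compound 3 (1.00 log units; beyond the scatter), so this position does not treat the two groups alike, although they match in heavy-atom count and ring types. Nothing measured here accounts for this step.

The compounds shown leave open whether the step follows the ring hetero atom or the point of attachment. A 1H-indol-5-yl or 1-benzothiophen-6-yl group on the core of compound 1 would separate the two.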